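The source may report more compounds than this note shows. Statements on the series, on what has been measured and on what is new or still open speak of the compounds shown alone.

Compound 1 `COC(=O)C1=C(C)NC(C)=C(C(=O)OC)C1c1c(-c2ccsc2)nc2sc(C)cn12`: 3520 nM
Compound 2 `COC(=O)C1=C(C)NC(C)=C(C(=O)OC)C1c1c(-c2ccncc2)nc2sc(C)cn12`: 9690 nM

In a functional assay on ileum (Cavia porcellus) for inhibition (on this read-out lower numbers stand for stronger inhibition and higher numbers for weaker inhibition), compound 2 has the higher of the two numbers at 9690 nM, which makes it the weaker inhibitor of this pair. Compound 3 `COC(=O)C1=C(C)NC(C)=C(C(=O)OC)C1c1c(-c2cccs2)nc2sc(C)cn12` differs from compound 2 by one change: thiophen-2-yl in place of pyridin-4-yl on an aromatic carbon. In words, thiophen-2-yl comes in place of pyridin-4-yl on an aromatic carbon.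

Among the compounds with values here, only one measured step bears on this: a 2.8-fold higher number from compound 1 to compound 2 (0.44 log units; beyond the scatter). That modest step removed thiophen-3-yl and brought in pyridin-4-yl. Compound 3 reverses the swap with the other thiophenyl attachment, so a modest step towards a lower number is expected. Within the data shown here, no measurement yet compares thiophen-2-yl with thiophen-3-yl, so the range stays wide. The expected change is a 2.2-fold lower number from compound 2 to compound 3 (0.33 log units; beyond the scatter). For compound 3 the estimated value is 4500 nM, with an expected range from 1800 nM to 11000 nM.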

Compound 3, half-maximal inhibitory concentration: 1370 nM
The estimate for compound 3 lay 3.3-fold (0.52 log units) above the measured number; measured number outside the range, below it.
By their numbers in this assay, from the lowest: compound 3; then compound 1; then compound 2.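

Within the thiophene pair, the point of attachment matters as well as the type of ring: in this assay, thiophen-2-yl in place of thiophen-3-yl gives a 2.6-fold lower number from compound 1 to compound 3 (0.41 log units; beyond the scatter) on this aromatic carbon, next to the ring nitrogen. Compared with pyridin-4-yl, thiophen-2-yl gives a 7.1-fold lower number from compound 2 to compound 3 (0.85 log units; beyond the scatter) and so makes compound 3 the strongest inhibitor of these three. Nothing available here explains why these rings differ.

The compounds shown leave open whether the low number belongs to thiophen-2-yl specifically or would also appear with a plain phenyl or a furan-2-yl ring. They also leave open whether adding a methyl group or a chlorine atom to the thiophen-2-yl ring would lower the number further or raise it.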